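Anilide variation on the piperazine-linked core in colon cells

The compounds below may be only part of what the source reports. "The series", "measured", "known", "first", "only" and "open" are said of these compounds alone.

Compound 1 `Cc1cccc(Cl)c1NC(=O)CN1CCN(c2nnc(Cc3ccncc3)c3ccccc23)CC1` and compound 2 `O=C(CN1CCN(c2nnc(Cc3ccccc3)c3ccccc23)CC1)Nc1ccc(Br)cc1` are the two members of this series measured so far in a functional assay on HT-29 cells (Homo sapiens) for cytotoxicity, read by MTT assay, with a stated time of 72 h; a higher number here means a weaker inhibitor, a lower number a stronger inhibitor. Compound 1 gives 22600 nM, the lowest of the two numbers, and compound 2 gives 60200 nM; the two compounds differ in more than one place, so their gap is read only as the two values show it. Compound 3 `O=C(CN1CCN(c2nnc(Cc3ccncc3)c3ccccc23)CC1)Nc1ccc(F)c(C(F)(F)F)c1` is not yet measured. It keeps the core of compound 1 and differs from it at one site: 4-fluoro-3-(trifluoromethyl)phenyl in place of 2-chloro-6-methylphenyl on an amide-type nitrogen. The change is a swap of one aromatic substitution pattern for another on the amide-type nitrogen, with no change in donor or acceptor count. No single-point comparison within the series shows how such a swap moves the number, so the expected step is small, in either direction, and most likely not beyond the scatter. On that basis the step from compound 1 to compound 3 is estimated at a 1.2-fold higher number from compound 1 to compound 3 (0.09 log units; within the scatter), and compound 3 is expected to give about 28000 nM in this assay, with a range from 9000 nM to 85000 nM.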

Compound 3, half-maximal inhibitory concentration: 1110 nM
Beside the measured number, compound 3's estimate is 25-fold (1.40 log units) above it; the whole stated range lies above it.
By their numbers in this assay, from the lowest: compound 3; then compound 1; then compound 2.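

The aryl group on the amide-type nitrogen is now shown to be a sensitive site in this assay: on the core of compound 1, 4-fluoro-3-(trifluoromethyl)phenyl in place of 2-chloro-6-methylphenyl gives a 20-fold lower number from compound 1 to compound 3 (1.31 log units; beyond the scatter) as the only structural change. Until now the series held no single-site comparison, so neither the reach of this position nor the size of a step there could be read from its values. Both groups count no hydrogen-bond donors or acceptors and no net charge, so the step comes without any change in those counts, and no measurement at hand bears on its origin.

Among these compounds, the swap changes several things at once, so the values leave open whether the step follows from gaining the fluorine, gaining the trifluoromethyl, or losing the chlorine or the methyl; a phenyl carrying only one of these groups, or an unsubstituted phenyl, would separate them. Also open, on these data alone, is how the number responds to a carboxylic acid or a primary amine on this ring, and whether the step holds on a core other than that of compound 1.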